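One Carbon Added to the Ester Chain

A few compounds are considered here, and "the series" means these few. Any claim that something is new, unique, unknown or untested is made for them only; others in the source may bear on it.

In an ADME assay on Vero cells (Chlorocebus sabaeus) for cytotoxicity, read by MTT assay, with a stated time of 72 h (a higher number here means that more compound is tolerated, a lower number that less compound is tolerated), compound 2 (`COC(=O)CN1CCN(c2c(F)cc3c(=O)c(C(=O)O)cn(C4CC4)c3c2OC)CC1C`) gives 500 ug/mL. For the measured compounds named here, its only measured neighbour, compound 1 (`COc1c(N2CCN(CC#N)C(C)C2)c(F)cc2c(=O)c(C(=O)O)cn(C3CC3)c12`), gives 354 ug/mL, and the two lie within the scatter of each other. Compound 3 (`COC(=O)CCN1CCN(c2c(F)cc3c(=O)c(C(=O)O)cn(C4CC4)c3c2OC)CC1C`) carries (methoxycarbonyl)methyl in place of the methoxycarbonyl of compound 2, on a saturated chain carbon bound to an amine nitrogen in a ring: (methoxycarbonyl)methyl in place of methoxycarbonyl on a saturated chain carbon bound to an amine nitrogen in a ring. Going by the values given here, only one measured step bears on this change. It touched the same place, with methoxycarbonyl replacing cyano, and came to a 1.4-fold higher number from compound 1 to compound 2 (0.15 log units; within the scatter). Among the compounds with values here, no measurement yet shows what lengthening this chain does, so that small step is the sole guide, and no direction can be argued from it. The estimated step is a 1.1-fold lower number from compound 2 to compound 3 (0.05 log units; within the scatter), which is expected to stay within the scatter. Compound 3 is expected at 450 ug/mL, with an estimated range of 240 ug/mL to 800 ug/mL.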

Compound 3, half-maximal cytotoxic concentration: > 1000 ug/mL
Compound 3 ended at the assay's limit (the forecaster's own chance of this, stated with the estimate: 15%); middle value at least 2.2-fold (0.34 log units) from the limit.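

Compound 3 stands at a limit of this assay, so its entry is a bound and not a number: the limit of > 1000 ug/mL in this assay, at which 1 of the 3 values shown sits.

For the compounds shown here, on a saturated chain carbon bound to an amine nitrogen in a ring, (methoxycarbonyl)methyl in place of methoxycarbonyl gives an at least 2.0-fold higher number from compound 2 to compound 3 (0.30 log units; that floor lies within the scatter), so this step alone does not establish a change. (Methoxycarbonyl)methyl in place of cyano gives an at least 2.8-fold higher number from compound 1 to compound 3 (0.45 log units; beyond the scatter), the first step at this place to clear the scatter, which the earlier step from nitrile to methoxycarbonyl did not do.

As far as these compounds go, how far compound 3 lies past the limit remains open, and with it the true size of both steps. Also open, from the compounds shown here alone, is how a longer chain, a carboxylic acid in place of the ester or an amine at this place would read in this assay.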